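Bromo to Fluoro in a Series of Weak Inhibitors

The source may hold more compounds than are shown below. What is called first, only, known or untested is meant among the compounds shown, and "the series" means these compounds.

Compound 1 `COC(=O)[C@@]1(C)C[C@@H](c2coc3ccc(Br)cc3c2=O)N(c2ccccc2)O1` reaches only the limit > 60000 nM in a functional assay on Caco-2 cells (Homo sapiens) for inhibition, read by sulforhodamine B assay, with a stated time of 48 h; a higher number here means a weaker inhibitor, a lower number a stronger inhibitor.
Compound 2 `O=c1c([C@@H]2C[C@H](c3ccccc3)ON2c2ccccc2)coc2ccc(F)cc12` gives 60000 nM in this assay.
Compound 3 `O=c1c([C@@H]2C[C@H](c3ccccc3)ON2c2ccccc2)coc2ccc(Br)cc12` again reaches only the limit > 60000 nM in this assay.

All three measured compounds sit at or next to the upper edge of what this assay can report. For the measured compounds named here, the one step that can be read is a number no higher from compound 3 to compound 2 (the limit leaves the size open), described as fluoro in place of bromo on an aromatic carbon. Going by these compounds, its size stays open because of the limit of > 60000 nM in this assay, at which 2 of the 3 values shown sit, so nothing can be said about whether the fluoro compound is any different from the bromo compound in this pair.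

Compound 4 `COC(=O)[C@@]1(C)C[C@@H](c2coc3ccc(F)cc3c2=O)N(c2ccccc2)O1` is not yet measured. It stands to compound 1 as compound 2 stands to compound 3: the change is fluoro in place of bromo on an aromatic carbon, and the place lines of the two changes agree word for word, so it is the same change made on a second core. How the core of compound 1 differs from that of compound 3 is not broken down here.

Since compound 1 is known only as a limit, the expected step of a number no higher from compound 1 to compound 4 (the limit leaves the size open) is an estimate resting on the open-sized step a number no higher from compound 3 to compound 2 (the limit leaves the size open), which gave no sign of a gain. Compound 4 is therefore expected to give about 60000 nM, in the range 30000 nM to 120000 nM, most likely reported again as a limit.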

Compound 4, half-maximal inhibitory concentration: 29500 nM
Compound 4: the middle estimate sits 2.0-fold (0.31 log units) above what was measured, outside the stated range (below it).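

In this assay, fluoro in place of bromo on an aromatic carbon of the core of compound 1 gives an at least 2.0-fold lower number from compound 1 to compound 4 (0.30 log units; that floor lies within the scatter), so this core shows no sign of a loss with the change, though the gain it may carry is not established as beyond the usual scatter. The same change on the core of compound 3 cannot be read for size, so the series does not show whether the change carries from one core to the other with the same effect: the same change on two cores in this assay, a number no higher (the limit leaves the size open) from compound 3 to compound 2 and an at least 2.0-fold lower number (0.30 log units; that floor lies within the scatter) from compound 1 to compound 4; the limit leaves it open whether they differ Both steps start from a compound known only as a limit, and this keeps their sizes open and leaves two cores that cannot be set against each other in number: the limit of > 60000 nM in this assay, at which 2 of the 4 values shown sit.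

Only bromo and fluoro appear on this aromatic carbon, so the compounds shown leave open how chloro, a nitrile or an amine would read at that place in this assay. They also leave open how the core of compound 4 would read with a carboxylic acid in place of its methyl ester.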